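This account rests on a few compounds, and the source may have more. Where it says the series, first, only, none or still open, it means among the compounds named here.

Compound 1 `CC(C)c1ccccc1NC(=O)N[C@H](C)c1ccccc1`: in an ADME assay on the whole organism with Oryza sativa as the target, tested at 10 uM (a lower number here means a stronger effect, a higher number a weaker effect of the compound at the concentration tested), compound 1 gives 17%.
Compound 2 `CC(C)c1ccccc1NC(=O)N[C@@H](C)c1ccccc1`: in this assay compound 2 gives 93%.
Compound 3 `CC(=O)c1cccc(NC(=O)N[C@@H](C)c2ccccc2)c1`: in this assay compound 3 gives 94%.

Compound 1 stands lowest of the three numbers in this assay, with compound 2 nearest and compound 3 furthest. Among the measured compounds shown here, the one measured step, a number 76 percentage points higher from compound 1 to compound 2 (beyond the scatter), rests on (the fact that compounds 1 and 2 differ only in the configuration as drawn).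

Compound 4 `C[C@@H](NC(=O)Nc1ccccc1Br)c1ccccc1` is reached from compound 1 by one change: bromo in place of isopropyl on an aromatic carbon. For the measured compounds named here, no measured step concerns this exchange of groups on the aromatic ring; the single step known is a change of configuration alone, which bears no direct comparison. The estimate for compound 4 therefore rests mainly on the value of compound 1 and carries wide uncertainty. Compound 4 is expected near 30%, between 8% and 65%, so that a number 13 percentage points higher from compound 1 to compound 4 (beyond the scatter) is expected.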

Compound 4, a percentage reported as activity, at one concentration (the size of the read-out at that concentration, not a potency): 94%
The estimate for compound 4 lay 64 percentage points below the measured number; measured number above the stated range.
By their numbers in this assay, from the lowest: compound 1; then compounds 2, 3 and 4 (each within the scatter of the next).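

In this assay, bromo in place of isopropyl on this aromatic carbon gives a number 77 percentage points higher from compound 1 to compound 4 (beyond the scatter). The low number of compound 1 therefore depends on the group at this place as well as on the configuration, and this single exchange is enough to lose it. Nothing at hand explains why the exchange has so large an effect.

On these data alone, it remains open whether methyl, ethyl, tert-butyl or chloro at this place would keep the low number. The compounds shown also do not tell whether a methoxy group would.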